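A few compounds are considered here, and "the series" means these few. Any claim that something is new, unique, unknown or untested is made for them only; others in the source may bear on it.

Compound 1 `COc1ccc2cc(C(C)c3nnc4n3N=C(c3ccc([N+](=O)[O-])cc3)CS4)ccc2c1` gives 15100 nM in a functional assay on HCT-116 cells (Homo sapiens) for inhibition, read by sulforhodamine B assay, with a stated time of 72 h; on this read-out higher numbers stand for weaker inhibition and lower numbers for stronger inhibition.
Compound 2 `COc1ccc2cc(C(C)c3nnc4n3N=C(c3ccc(F)cc3)CS4)ccc2c1` gives 13100 nM in this assay.
Compound 3 `COc1ccc2cc(C(C)c3nnc4n3N=C(c3ccc(C(F)(F)F)cc3)CS4)ccc2c1` gives 10800 nM in this assay.

Compound 3 has the lowest of the three numbers, but the gaps to the others are small: a 1.4-fold lower number from compound 1 to compound 3 (0.15 log units; within the scatter) and a 1.2-fold lower number from compound 2 to compound 3 (0.08 log units; within the scatter) both fall within the scatter, so the three compounds cannot be told apart on these measurements.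

Compound 4 `COc1ccc2cc(C(C)c3nnc4n3N=C(c3ccc(C)cc3)CS4)ccc2c1` differs from compound 3 in one place: methyl in place of trifluoromethyl on an aromatic carbon. The measured steps that bear on this change are the three swaps on the same aromatic carbon, a 1.2-fold lower number from compound 1 to compound 2 (0.06 log units; within the scatter), a 1.4-fold lower number from compound 1 to compound 3 (0.15 log units; within the scatter) and a 1.2-fold lower number from compound 2 to compound 3 (0.08 log units; within the scatter), each within the scatter. Three different groups at that position have given much the same number, so a fourth group there is expected to leave this assay unchanged beyond the scatter.

Compound 4 is therefore expected to give about 12000 nM, within a range of 6000 nM to 25000 nM. This estimate amounts to an expected step of a 1.1-fold higher number from compound 3 to compound 4 (0.05 log units; within the scatter), inside the scatter.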

Compound 4, half-maximal inhibitory concentration: 10200 nM
The estimate for compound 4 lay 1.2-fold (0.07 log units) above the measured number, and the stated range covers the measured number.
By their numbers in this assay, from the lowest: compounds 4, 3, 2 and 1 (each within the scatter of the next).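

Methyl is the fourth group on this aromatic carbon and the only one of the four built from carbon and hydrogen alone, yet it does not separate from the others. In this assay, the change to methyl gives a 1.1-fold lower number from compound 3 to compound 4 (0.02 log units; within the scatter), a 1.3-fold lower number from compound 2 to compound 4 (0.11 log units; within the scatter) and a 1.5-fold lower number from compound 1 to compound 4 (0.17 log units; within the scatter), so each step stays within the scatter. Across compounds 1 to 4, then, the replacement of nitro, fluoro or trifluoromethyl by methyl produces no readable change at this position.

No measurement shown explains why these four compounds cannot be told apart. Going by these compounds, whether an amine, a carboxylic acid or a longer chain on this carbon would move the number beyond the scatter remains open, as does the effect of changes elsewhere on the shared core.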